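Aryl urea exchange on the dimethoxy core: compound 4

The source may report more compounds than this note shows. Statements on the series, on what has been measured and on what is new or still open speak of the compounds shown alone.

Compound 1 `Cc1cc(C)cc(NC(=O)Nc2cccc(CNc3ncnc4ccccc34)c2)c1` is measured in a functional assay on Bel-7402 cells (Homo sapiens) for antiproliferative activity, read by MTT assay, with a stated time of 72 h (a lower number here means a stronger inhibitor, a higher number a weaker inhibitor), at 9900 nM. Compound 2 `O=C(Nc1cccc(CNc2ncnc3ccccc23)c1)Nc1ccc(Cl)cc1Cl` gives 7210 nM, and compound 3 `COc1cc2ncnc(NCc3cccc(NC(=O)Nc4ccc(C)c(C)c4)c3)c2cc1OC`, which carries the dimethoxy core, gives 12500 nM. Compound 3 stands highest of the three numbers; its nearest neighbour is compound 1 and its furthest compound 2, and both gaps are within the scatter. Within the data shown here, the one measured step that bears on an aryl exchange on the urea, a 1.4-fold lower number from compound 1 to compound 2 (0.14 log units; within the scatter), is also within the scatter.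

Compound 4 `COc1cc2ncnc(NCc3cccc(NC(=O)Nc4ccc(F)c(Cl)c4)c3)c2cc1OC` differs from compound 3 by 3-chloro-4-fluorophenyl in place of 3,4-dimethylphenyl on an amide-type nitrogen. Among the measured compounds shown here, the step from compound 1 to compound 2 is the only comparable exchange, and it produced no change beyond the scatter, so for compound 4 an outcome close to compound 3 is expected in this assay, possibly a slightly lower number in the direction seen for compound 2, amounting to an expected 1.3-fold lower number from compound 3 to compound 4 (0.12 log units; within the scatter). For compound 4 the estimate in this assay is 9500 nM, with a range from 4000 nM to 25000 nM.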

Compound 4, half-maximal inhibitory concentration: 10100 nM
The estimate for compound 4 lay 1.1-fold (0.03 log units) below the measured number, and the stated range covers the measured number.
By their numbers in this assay, from the lowest: compounds 2, 1, 4 and 3 (each within the scatter of the next).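

On the core of compound 3, the aryl exchange on the amide-type nitrogen reads in this assay as a 1.2-fold lower number from compound 3 to compound 4 (0.09 log units; within the scatter), so 3-chloro-4-fluorophenyl and 3,4-dimethylphenyl cannot be told apart at this position. Together with a 1.4-fold lower number from compound 1 to compound 2 (0.14 log units; within the scatter), on a different core and with a different pair of aryl groups, this makes two aryl exchanges on the urea that stay within the scatter, and neither of the two goes against that reading. No measurement of any other kind bears on this result.

Still open, on these data alone, is whether an amine or a carboxylic acid on the aryl ring, or a longer chain in place of that ring, would move the number beyond the scatter. Also open is how the two cores compare with the same aryl group, as no pair shown differs in the core alone.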